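Anilino substituent changes in a shared tricyclic series

A few compounds are considered here, and "the series" means these few. Any claim that something is new, unique, unknown or untested is made for them only; others in the source may bear on it.

Compound 1 `O=C1C(Nc2ccc(I)cc2)=CC(=O)c2c1nc1n2[C@H]2OC[C@@H](O)[C@H]2OC1` carries an iodo group on the aryl ring; in a functional assay on HeLa cells (Homo sapiens) for inhibition, read by sulforhodamine B assay (a higher number here means a weaker inhibitor, a lower number a stronger inhibitor), compound 1 gives 4010 nM. Compound 2 `O=C1C(Nc2ccc(C(F)(F)F)cc2)=CC(=O)c2c1nc1n2[C@H]2OC[C@@H](O)[C@H]2OC1` bears trifluoromethyl instead; in this assay compound 2 gives 8920 nM, a step of a 2.2-fold higher number from compound 1 to compound 2 (0.35 log units; beyond the scatter). Compound 3 `COc1ccc(NC2=CC(=O)c3c(nc4n3[C@H]3OC[C@@H](O)[C@H]3OC4)C2=O)cc1` bears methoxy. In this assay compound 3 gives only a limit, > 8000 nM, so its place among the numbers is not fixed. The step of an at least 1.9-fold higher number from compound 1 to compound 3 (0.29 log units; that floor lies within the scatter) has a floor only, and the step that the limit leaves unreadable from compound 2 to compound 3 cannot be read because of the limit of > 8000 nM in this assay, at which 1 of the 3 values shown sits. Compound 4 `O=C1C(Nc2cccc(Cl)c2)=CC(=O)c2c1nc1n2[C@H]2OC[C@@H](O)[C@H]2OC1` differs from compound 3 by 3-chlorophenyl in place of 4-methoxyphenyl on an amine nitrogen. Going by the values given here, no measured step carries this exact change; the nearest guide is an at least 1.9-fold higher number from compound 1 to compound 3 (0.29 log units; that floor lies within the scatter) read backwards, so 3-chlorophenyl in place of 4-methoxyphenyl is expected to give a lower number in this assay, a step of about an at least 1.6-fold lower number from compound 3 to compound 4 (0.20 log units; that floor lies within the scatter). Compound 4 is therefore estimated at 5000 nM in this assay, between 2000 nM and 14000 nM.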

Compound 4, half-maximal inhibitory concentration: 7970 nM
Compound 4: the middle estimate sits 1.6-fold (0.20 log units) below what was measured; the measured number falls inside the stated range.
By their numbers in this assay, from the lowest: compounds 1, 4 and 2 (each within the scatter of the next, the first and the last beyond it).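

In this assay, 3-chlorophenyl in place of 4-iodophenyl on the amine nitrogen gives a 2.0-fold higher number from compound 1 to compound 4 (0.30 log units; within the scatter). 3-chlorophenyl in place of 4-(trifluoromethyl)phenyl gives a 1.1-fold lower number from compound 2 to compound 4 (0.05 log units; within the scatter). Compound 4 therefore cannot be separated from either compound 1 or compound 2, even though those two lie beyond the scatter of each other, so this change of aryl group does not open a clear gap at this position. 3-chlorophenyl in place of 4-methoxyphenyl gives a number no higher from compound 3 to compound 4 (the limit leaves the size open). The size of this step cannot be read because compound 3 has only a limit: the limit of > 8000 nM in this assay, at which 1 of the 4 values shown sits.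

The compounds shown leave open how 3-chlorophenyl compares with 4-chlorophenyl, a pair that would separate the chloro group from its place on the ring. They also leave open what an amine or a carboxylic acid on the aryl ring, or a longer alkyl chain in place of that ring, would do in this assay on this core.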